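This account rests on a few compounds, and the source may have more. Where it says the series, first, only, none or still open, it means among the compounds named here.

- compound 1 `CN1C/C(=C\c2cccnc2)C(=O)/C(=C/c2cc([N+](=O)[O-])ccc2F)C1`: 6630 nM
- compound 2 `CN1C/C(=C\c2ccncc2)C(=O)/C(=C/c2ccc(F)cc2Br)C1`: 9200 nM
- compound 3 `O=C1/C(=C/c2cccnc2)CNC/C1=C\c1ccccc1F`: 21000 nM

All three values come from a functional assay on HepG2 cells (Homo sapiens) for cytotoxicity, read by MTT assay, with a stated time of 24 h; a lower number here means a stronger inhibitor, a higher number a weaker inhibitor. Compound 3 stands highest of the three, and its distance to each of the other two lies beyond the scatter. For the measured compounds named here, no two measured compounds differ in one place only, so no measured step is available as a guide.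

Compound 4 `N#Cc1ccc(S(=O)(=O)N2C/C(=C\c3cccnc3)C(=O)/C(=C/c3ccccc3F)C2)cc1` has (4-cyanophenyl)sulfonyl in place of hydrogen on an amine nitrogen in a ring of compound 3 ((4-cyanophenyl)sulfonyl in place of hydrogen on an amine nitrogen in a ring). Going by the values given here, compound 3 is the only measured compound with hydrogen on that nitrogen. Compound 1 at 6630 nM and compound 2 at 9200 nM both carry a group there and both show lower numbers, but they also differ from compound 3 elsewhere, so this is weak support. A move to a lower number in this assay, beyond the scatter, is expected, and the expected size is a 3.5-fold lower number from compound 3 to compound 4 (0.54 log units; beyond the scatter). For compound 4 the estimate is 6000 nM, with an expected range of 1800 nM to 20000 nM.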

Compound 4, half-maximal inhibitory concentration: 6600 nM
The estimate for compound 4 lay 1.1-fold (0.04 log units) below the measured number; the range from low to high includes it.
By their numbers in this assay, from the lowest: compounds 4, 1 and 2 (each within the scatter of the next); then compound 3.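

In this assay, the amine nitrogen in the ring can now be read through a single change: (4-cyanophenyl)sulfonyl in place of hydrogen gives a 3.2-fold lower number from compound 3 to compound 4 (0.50 log units; beyond the scatter), a modest step. For the compounds shown here, compound 1 and compound 2 also carry a group on this nitrogen but differ elsewhere, so only this pair shows that the position tolerates a group of 11 heavy atoms with a lower number, not a higher one. Nothing measured here bears on why the number moves.

On these data alone, it remains open which part of the entering group matters, the sulfonyl, the aromatic ring or the nitrile; a benzenesulfonyl or an acetyl group on this nitrogen would begin to separate them. Whether the same step holds with other aromatic groups on the shared core is also unresolved.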